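Swapping a benzylamino link for a phenoxy link

The compounds below may be only part of what the source reports. "The series", "measured", "known", "first", "only" and "open" are said of these compounds alone.

Compound 1 `COc1ccc(CNc2nc3cc(N)cc(N)c3nc2-c2ccccc2)cc1OC`: in a functional assay on HT-29 cells (Homo sapiens) for inhibition, read by sulforhodamine B assay, with a stated time of 48 h (a higher number here means that more compound is tolerated, a lower number that less compound is tolerated), compound 1 gives < 100000 nM, which is a limit of the assay and not a number.
Compound 2 `Nc1cc(N)c2nc(-c3ccccc3)c(NCc3ccc(F)cc3)nc2c1`: in this assay compound 2 gives < 100000 nM, again only a limit.
Compound 3 `COc1ccc(CNc2nc3cc(N)cc(N)c3nc2-c2ccccc2)cc1`: in this assay compound 3 gives < 100000 nM, also a limit.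

Compound 2 therefore stands at the limit, and it is not alone there: all three values shown sit at that same limit (the limit of < 100000 nM in this assay, at which 3 of the 3 values shown sit). None of the steps between the measured compounds can be read. The step that the two limits leave unreadable from compound 1 to compound 2, the step that the two limits leave unreadable from compound 1 to compound 3 and the step that the two limits leave unreadable from compound 2 to compound 3 all remain unreadable, so nothing is known about how the groups at this position move the read-out.

The new compound 4 `Nc1cc(N)c2nc(-c3ccccc3)c(Oc3ccc(F)cc3)nc2c1` differs from compound 2 in one place: 4-fluorophenoxy in place of (4-fluorobenzyl)amino on an aromatic carbon. No measured step bears on this change in a readable way, so no direction can be derived from the numbers shown. Among the measured compounds shown here, the only guide is that every compound so far returned a limit.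

Compound 4 is expected to behave like its neighbours, with an estimated value of 50000 nM, ranging from 5000 nM to 100000 nM. That means an expected step that the limit leaves unreadable from compound 2 to compound 4, most likely again reported as a limit.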

Compound 4, concentration lethal to 50% of the cells: < 100000 nM
Compound 4: only a limit was reported; the forecaster's own chance of this, stated with the estimate: 70%; the middle value lies beyond the limit too.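

In this assay compound 4 gives < 100000 nM, which is a limit of the assay and not a number. Compound 2 also sits at a limit, and the step between compound 2 and compound 4 cannot be read. The same holds across the series: the limit of < 100000 nM in this assay, at which 4 of the 4 values shown sit.

The compounds shown leave open whether 4-fluorophenoxy in place of (4-fluorobenzyl)amino changes the read-out at all, and what actual value any of the four compounds would give.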